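The source may hold more compounds than are shown below. What is called first, only, known or untested is meant among the compounds shown, and "the series" means these compounds.

Measured compounds in a functional assay on NCI-H1975 cells (Homo sapiens) for antiproliferative activity, read by CCK-8 assay, with a stated time of 72 h; a higher number here means a weaker inhibitor of growth, a lower number a stronger inhibitor of growth:

compound 1 `CC[C@@H]1C(=O)N(C)c2cnc(Nc3ccc(S(=O)(=O)NCCO)cc3)nc2N1C1CCCC1` gives 2100 nM
compound 2 `CCC1C(=O)N(C)c2cnc(-n3ccc4cc(C(=O)NC)ccc43)nc2N1c1ccn(C)n1` gives 35700 nM
compound 3 `CCC1C(=O)N(C)c2cnc(Nc3ccc(S(=O)(=O)NCC(C)C)cc3)nc2N1c1ccn(C)n1` gives 15000 nM

Compound 2 stands with the highest number of the three, that is, as the weakest inhibitor of growth in this set. The nearest is compound 3, whose number is lower by a gap beyond the scatter; the furthest is compound 1, whose number is lower by a much wider gap, also beyond the scatter. No two of these three compounds differ in a single place, so no measured step can be read from them.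

Compound 4 `CCCCNC(=O)c1ccc2c(ccn2-c2ncc3c(n2)N(c2ccn(C)n2)C(CC)C(=O)N3C)c1` is not yet measured. It differs from compound 2 in one place: propyl in place of hydrogen on a saturated chain carbon bound to an amide-type nitrogen. Among the measured compounds shown here, nothing among the measured compounds tells what such a change does in this assay; the closest guidance is only that compound 2 itself sits at the weak end of the range. The step from compound 2 to compound 4 is therefore expected to be small, most likely within the scatter, with a slight lean toward a lower number, as given by a 1.4-fold lower number from compound 2 to compound 4 (0.15 log units; within the scatter).

For compound 4 the value expected in this assay is 25000 nM, with a range from 8000 nM to 80000 nM.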

Compound 4, concentration for 50% growth inhibition: 12000 nM
Compound 4: the middle estimate sits 2.1-fold (0.32 log units) above what was measured; the measured number falls inside the stated range.
By their numbers in this assay, from the lowest: compound 1; then compounds 4 and 3 (each within the scatter of the next); then compound 2.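

In this assay, among the compounds shown here, the change from methylcarbamoyl to butylcarbamoyl gives a 3.0-fold lower number from compound 2 to compound 4 (0.47 log units; beyond the scatter) and provides the first single-place step. This shows that the saturated chain carbon bound to an amide-type nitrogen is a position where substitution can alter the read-out: propyl in place of hydrogen is tolerated here and shifts the number toward stronger inhibition of growth, although the step is only modest. Nothing shown accounts for this shift, so the step stands as an observation without an explanation.

On these data alone, a single step does not establish a trend with chain length, so it remains open whether ethyl or propyl in place of the hydrogen would give part of the same shift, or whether a longer chain such as hexyl would extend, hold or reverse it. As far as these compounds go, it is also open how a chain carrying an amine or a carboxylic acid would read at this position, and whether the same change would give a step of similar size on other members.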